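Working notes: from compound 2 to compound 3

The compounds below may be only part of what the source reports. "The series", "measured", "known", "first", "only" and "open" are said of these compounds alone.

Compound 1 `O=[N+]([O-])c1ccc2nn(Cc3ccccc3)c(OCCBr)c2c1`: > 256000 nM
Compound 2 `COC(=O)COc1c2cc([N+](=O)[O-])ccc2nn1Cc1ccccc1`: > 256000 nM
Compound 3 `COC(=O)CCOc1c2cc([N+](=O)[O-])ccc2nn1Cc1ccccc1`: not yet measured

All readings come from an ADME assay on L929 cells (Mus musculus) for cytotoxicity, read by resazurin assay, with a stated time of 48 h; a higher number here means that more compound is tolerated, a lower number that less compound is tolerated. Compound 2 gives > 256000 nM, which is a limit of the assay and not a number. Compound 1 gives > 256000 nM, which is also a limit. Both measured compounds therefore stand at the same point: the limit of > 256000 nM in this assay, at which 2 of the 2 values shown sit.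

The change now followed is (methoxycarbonyl)methyl in place of methoxycarbonyl on a saturated chain carbon bound to an oxygen on an aromatic ring, which turns (methoxycarbonyl)methoxy into 2-(methoxycarbonyl)ethoxy. Within the data shown here, the only measured step bearing on it acts at the same place: a step that the two limits leave unreadable from compound 1 to compound 2. That step gives no size to carry forward, so the forecast for this assay favours neither direction.

The expectation rests on compound 2, at > 256000 nM, a limit. The expected change is a number no higher from compound 2 to compound 3 (the limit leaves the size open), with no shift beyond the scatter anticipated. For compound 3 the estimated value is 256000 nM. The expected range for compound 3 runs from 100000 nM to 512000 nM, and a report as a limit alone is the likeliest outcome.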

Compound 3, concentration lethal to 50% of the cells: > 256000 nM
Compound 3: a limit, no number; the forecaster's own chance of this, stated with the estimate: 80%; the middle value lies on the limit itself.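

No new step can be read among compound 1, compound 2 and compound 3 in this assay, because each stands at a limit and none gives a number: the limit of > 256000 nM in this assay, at which 3 of the 3 values shown sit.

The compounds shown leave open whether the bromo, methoxycarbonyl and (methoxycarbonyl)methyl groups differ at all in this assay.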